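Adding a Second Fluoro to a Rotarod Series

This account rests on a few compounds, and the source may have more. Where it says the series, first, only, none or still open, it means among the compounds named here.

Compound 1, `NC(=O)/C=C1\CCc2ccc(Cl)cc21`: in a functional assay on the whole organism with Mus musculus as the target, in the rotarod test (a lower number here means that less compound is needed, a higher number that more compound is needed for the effect), compound 1 gives 221 mg/kg.
Compound 2, `O=C(/C=C1\CCc2cc(F)ccc21)NC1CC1`: in this assay compound 2 gives 193 mg/kg.
Compound 3, `Cc1cccc2c1/C(=C/C(N)=O)CC2`: in this assay compound 3 gives 56 mg/kg.

These three compounds share one core and differ in the groups on it and on the amide. Among the three numbers, compound 2 stands second highest. Its nearest neighbour is compound 1, whose number lies within the usual scatter of that of compound 2, so no order between these two can be read. Compound 3 stands furthest away, with a lower number that lies beyond the scatter, so less of compound 3 is needed than of compound 2.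

Compound 4, `O=C(/C=C1\CCc2cc(F)cc(F)c21)NC1CC1`, has not yet been measured in this assay. It differs from compound 2 in one place: fluoro in place of hydrogen on an aromatic carbon. Among the compounds with values here, no pair of measured compounds differs in just this way, so the measured numbers give no guide to the size of such a step. A step not beyond the scatter, in either direction, is expected in this assay. The expected change is therefore a 1.0-fold lower number from compound 2 to compound 4 (0.01 log units; within the scatter). Compound 4 is estimated to give about 190 mg/kg, with a range from 80 mg/kg to 420 mg/kg.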

Compound 4, dose for half-maximal effect: 81 mg/kg
Beside the measured number, compound 4's estimate is 2.3-fold (0.37 log units) above it; the range from low to high includes it.
By their numbers in this assay, from the lowest: compounds 3 and 4 (each within the scatter of the next); then compounds 2 and 1 (each within the scatter of the next).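

Fluoro in place of hydrogen on the aromatic carbon ortho to a fused ring and meta to the existing fluoro group gives, in this assay, a 2.4-fold lower number from compound 2 to compound 4 (0.38 log units; beyond the scatter). Within the data shown here, this is the first change that can be read on its own, since the earlier compounds all differ in more than one place, and it shows that this one added fluoro is enough to shift the number beyond the usual scatter, so that less of compound 4 is needed for the effect. The data offer no measurement that bears on why this step occurs.

A single step cannot show whether the gain belongs to fluoro itself or would also appear with another group on the same carbon, such as methoxy, hydroxy or an amine. It also leaves open whether the same change would give a step of similar size with a different group on the amide nitrogen, such as a longer chain in place of the cyclopropyl group, or on the unsubstituted amide.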